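This account rests on a few compounds, and the source may have more. Where it says the series, first, only, none or still open, it means among the compounds named here.

Measured so far in a functional assay on SK-BR-3 cells (Homo sapiens) for antiproliferative activity, read by MTT assay, with a stated time of 72 h; a higher number here means a weaker inhibitor, a lower number a stronger inhibitor:
- compound 1 `C/C=C1/[C@H](O[C@@H]2O[C@H](CO)[C@@H](O)[C@H](O)[C@H]2O)OC=C(C(=O)OC)[C@H]1CC(=O)OCc1ccc2c(c1)OCCO2`: > 15000 nM
- compound 2 `C/C=C1/[C@H](O[C@@H]2O[C@H](COC(C)=O)[C@@H](OC(C)=O)[C@H](OC(C)=O)[C@H]2OC(C)=O)OC=C(C(=O)OC)[C@H]1CC(=O)OCCC1CCCCC1`: > 15000 nM
- compound 3 `C/C=C1/[C@H](O[C@@H]2O[C@H](CO)[C@@H](O)[C@H](O)[C@H]2O)OC=C(C(=O)O)[C@H]1CC(=O)O`: > 50000 nM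

On these data alone, compound 1 stands only at the limit of > 15000 nM in this assay, at which 2 of the 3 values shown sit, which is a limit of this assay and not a number, so its true half-maximal inhibitory concentration is unknown. Compound 2 likewise returns only a limit in this assay. Compound 3 returns only a limit as well, namely (the limit of > 50000 nM in this assay, at which 1 of the 3 values shown sits). Among the compounds with values here, with every measured value a limit, no ordering of the three compounds is possible and no step between them can be sized; all that the numbers show is that none of the three reaches a measurable inhibition of proliferation within the range of this assay.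

Compound 4 `C/C=C1/[C@H](O[C@@H]2O[C@H](CO)[C@@H](O)[C@H](O)[C@H]2O)OC=C(C(=O)OC)[C@H]1CC(=O)OCCc1ccc(F)cc1` differs from compound 1 by 4-fluorobenzyl in place of 2,3-dihydro-1,4-benzodioxin-6-yl on a saturated chain carbon bound to an oxygen next to a carbonyl group. Within the data shown here, no measured pair speaks to such a change. The expectation is therefore anchored to compound 1 alone: the step that the limit leaves unreadable from compound 1 to compound 4 is expected to be none beyond the scatter, and compound 4 is most likely to return a limit again in this assay. Compound 4 is estimated at 20000 nM, with a range from 5000 nM to 60000 nM.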

Compound 4, half-maximal inhibitory concentration: > 20000 nM
Compound 4 gave a limit, no number; the forecaster's own chance of this, stated with the estimate: 70%; the middle value sits exactly at the limit.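

In this assay compound 4 gives > 20000 nM, a limit and not a number. Compound 1 likewise stands at a limit, > 15000 nM. Within the data shown here, no step between compound 1 and compound 4 can therefore be read. The compounds shown leave open whether any of them has a measurable half-maximal inhibitory concentration in this assay, and what exchanging the two groups does to it.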